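This account rests on a few compounds, and the source may have more. Where it says the series, first, only, none or still open, it means among the compounds named here.

Measured in a functional assay on L1210 cells (Mus musculus) for antiproliferative activity, read by cell counting, with a stated time of 2 days; a higher number here means a weaker inhibitor, a lower number a stronger inhibitor:
compound 1 `COc1ccc(Nc2nc(N)c(C(=O)c3ccccc3)s2)cc1`: 850 nM
compound 2 `COc1ccc(Nc2nc(N)c(C(=O)c3ccc(Br)cc3)s2)cc1`: 110 nM
compound 3 `COc1ccc(Nc2nc(N)c(C(=O)c3ccc([N+](=O)[O-])cc3)s2)cc1`: 280 nM

Compound 2 has the lowest number of the three, which makes it the strongest inhibitor among them in this assay. Compound 4 `COc1ccc(Nc2nc(N)c(C(=O)c3ccccc3OC)s2)cc1` has not yet been measured. Its difference from compound 2 is 2-methoxyphenyl in place of 4-bromophenyl on a carbonyl carbon.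

Within the data shown here, no measured step tests the 2-methoxyphenyl group, so the evidence is indirect. Compound 4 carries no bromo, and bromo in place of hydrogen gave a 7.7-fold lower number from compound 1 to compound 2 (0.89 log units; beyond the scatter). Nitro in place of hydrogen gave the smaller 3.0-fold lower number from compound 1 to compound 3 (0.48 log units; beyond the scatter), and nitro in place of bromo gave a 2.5-fold higher number from compound 2 to compound 3 (0.41 log units; beyond the scatter). Any group other than bromo therefore has only a limited record here. A higher number than that of compound 2 is expected, beyond the scatter and somewhat smaller than the bromo step. The estimated change is a 5.0-fold higher number from compound 2 to compound 4 (0.70 log units; beyond the scatter). For compound 4 the estimated value is 550 nM, with an expected range from 150 nM to 2000 nM.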

Compound 4, half-maximal inhibitory concentration: 31 nM
Compound 4: middle estimate off by 18-fold (1.25 log units), on the high side, and the stated range ends above it.
By their numbers in this assay, from the lowest: compound 4; then compound 2; then compound 3; then compound 1.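

In this assay, the 2-methoxyphenyl group on the carbonyl carbon goes beyond what the bromo and nitro compounds showed, giving a 3.5-fold lower number from compound 2 to compound 4 (0.55 log units; beyond the scatter). Against the unsubstituted phenyl, the same group gives a 27-fold lower number from compound 1 to compound 4 (1.44 log units; beyond the scatter), the only large step among those shown. So the best-performing group at this carbonyl carbon need not be 4-bromophenyl, and a methoxy on the ring can lower the number further than bromo does, although compound 4 changes both the group and where it sits relative to compound 2. Nothing measured here explains this gain.

The compounds shown leave open whether the gain belongs to the methoxy itself or to its place on the ring, which 4-methoxyphenyl and 2-bromophenyl groups would separate. On these data alone, how an ethoxy or a hydroxyl in place of the methoxy would read also stays open.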